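This account rests on a few compounds, and the source may have more. Where it says the series, first, only, none or still open, it means among the compounds named here.

Measured compounds:
compound 1 `CCCc1ccncc1C#Cc1cc(Cl)ccc1OCC(=O)O`: in an assay on CHO cells for displacement of a labelled ligand from prostaglandin D2 receptor 2 (Homo sapiens), read by scintillation counting (on this read-out lower numbers stand for stronger inhibition and higher numbers for weaker inhibition), compound 1 gives 4.3 nM
compound 2 `Cc1ccc(S(=O)(=O)NC(C)C)cc1C#Cc1cc(Cl)ccc1OCC(=O)O`: in this assay compound 2 gives 3.4 nM

Compound 2 has the lower of the two numbers, but the gap to compound 1 lies within the scatter, so no difference between the two is established on these data.

Compound 3 `Cc1ccc(S(=O)(=O)N(C)CC(C)C)cc1C#Cc1cc(Cl)ccc1OCC(=O)O` has not yet been measured. Against compound 2 it differs in one place: isobutyl(methyl)amino in place of isopropylamino on a sulfonyl sulfur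

For the measured compounds named here, no step between measured compounds is known, so nothing measured tells how a change on the sulfonyl sulfur moves the number in this assay. The expectation is a small step in either direction, not clearly beyond the scatter. Compound 3 is expected to give about 4.5 nM, with a range from 1.5 nM to 14 nM, in this assay. The expected step is a 1.3-fold higher number from compound 2 to compound 3 (0.12 log units; within the scatter).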

Compound 3, inhibition constant: 4.2 nM
For compound 3 the middle estimate is 1.1-fold (0.03 log units) above the measured one; the measured number falls inside the stated range.
By their numbers in this assay, from the lowest: compounds 2, 3 and 1 (each within the scatter of the next).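

In this assay, isobutyl(methyl)amino in place of isopropylamino on a sulfonyl sulfur gives a 1.2-fold higher number from compound 2 to compound 3 (0.09 log units; within the scatter), so compound 2 and compound 3 are not told apart. For the compounds shown here, this is the first step measured at this position, and it shows that the number stays within the scatter even though the entering group has more heavy atoms and, unlike isopropylamino, no hydrogen-bond donor. No measurement here accounts for this result.

This single step does not show whether the position would respond to other groups on the sulfonyl sulfur, such as a morpholine ring, a longer chain ending in a carboxylic acid, or a primary amine. It also leaves open whether the donor or the added carbons matter on their own, as the two differences arrive together in compound 3.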